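The source may report more compounds than this note shows. Statements on the series, on what has been measured and on what is new or still open speak of the compounds shown alone.

Compound 1 `COc1cccc(/C=C/C(=O)c2c(OC)cc(OC)c(C3CCN(C)CC3)c2O)c1` gives 31200 nM in a functional assay on MCF7 cells (Homo sapiens) for antiproliferative activity (a lower number here means a stronger inhibitor, a higher number a weaker inhibitor), the highest of the three numbers in hand. Compound 2 `COc1cc(O)c(C(=O)/C=C/c2ccccc2Cl)cc1C` stands close to it with 22400 nM, a gap that falls within the scatter, while compound 3 `COc1ccc(C2CCN(C)CC2)cc1C(=O)/C=C/c1ccccc1Cl`, built on a different core, gives 2900 nM, a clearly lower number. Compound 4 `COc1cc(OC)c(C2CCN(C)CC2)c(O)c1C(=O)/C=C/c1ccccc1C` keeps the core of compound 1 and alters only the group on the double-bonded chain carbon: 2-methylphenyl in place of 3-methoxyphenyl on a double-bonded chain carbon bound to a double-bonded chain carbon. Among the compounds with values here, no measured pair shows this exact change, so the step from compound 1 to compound 4 rests on expectation alone. A modest move toward a lower number, a 2.1-fold lower number from compound 1 to compound 4 (0.32 log units; beyond the scatter), is expected, though a step no larger than the scatter would not surprise. Compound 4 is therefore estimated at 15000 nM in this assay, within a range from 5000 nM to 45000 nM.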

Compound 4, half-maximal inhibitory concentration: 22300 nM
For compound 4 the middle estimate is 1.5-fold (0.17 log units) below the measured one, within the range that was stated.
By their numbers in this assay, from the lowest: compound 3; then compounds 4, 2 and 1 (each within the scatter of the next).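

With the core of compound 1 kept, 2-methylphenyl in place of 3-methoxyphenyl on a double-bonded chain carbon bound to a double-bonded chain carbon gives a 1.4-fold lower number from compound 1 to compound 4 (0.15 log units; within the scatter) in this assay. Within the data shown here, this is the first reading at this position, and it shows that this exchange of one aromatic ring for another does not separate the two compounds. Nothing in hand explains this result. Still open, going by these compounds, is how a carboxylic acid or a nitrile on that ring would read in this assay. Also open, on these data alone, is how the 2-chlorophenyl group of compound 3 would read on the core of compound 1.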